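Methoxy in place of hydroxy on the chlorophenyl ring

The compounds below may be only part of what the source reports. "The series", "measured", "known", "first", "only" and "open" are said of these compounds alone.

Measured so far:
compound 1 `O=C(Nc1cccc(-n2cc(-c3ccncc3)c(-c3cc(O)cc(Cl)c3)n2)c1)Nc1ccc(Cl)c(C(F)(F)F)c1` — 92%
compound 2 `O=C(Nc1cccc(-n2cc(-c3ccncc3)c(-c3cc(O)cc(Cl)c3)n2)c1)Nc1ccc(Cl)c(Cl)c1` — 105%
compound 3 `COc1cc(Cl)cc(-c2nn(-c3cccc(NC(=O)Nc4cc(C(F)(F)F)cc(C(F)(F)F)c4)c3)cc2-c2ccncc2)c1` — 95%

All three numbers come from a functional assay on NCI/ADR-RES cells (Homo sapiens) for inhibition, read by sulforhodamine B assay, with a stated time of 48 h, tested at 0.1 uM; a lower number here means a stronger effect, a higher number a weaker effect of the compound at the concentration tested. Compound 2 stands with the highest of the three values: compound 1 lies below it, as a number 13 percentage points higher from compound 1 to compound 2 (beyond the scatter) shows, while the value of compound 3 sits within the scatter of that of compound 2, so no order between compound 2 and compound 3 can be read.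

Compound 4 `COc1cc(Cl)cc(-c2nn(-c3cccc(NC(=O)Nc4ccc(Cl)c(Cl)c4)c3)cc2-c2ccncc2)c1` is not yet measured. It differs from compound 2 in one place, (methyl in place of hydrogen on an oxygen on an aromatic ring). For the measured compounds named here, the single measured step concerns a different position, chloro in place of trifluoromethyl on an aromatic carbon, and does not bear on this change. Compound 3 carries the methoxy group but also differs from compound 2 at the urea aryl, so only its value can be set beside that of compound 2: the two are within the scatter of each other.

With nothing pointing to a shift, the step to compound 4 is expected to stay within the scatter, a number 5 percentage points lower from compound 2 to compound 4 (within the scatter). The estimate for compound 4 in this assay is 100%, between 85% and 115%.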

Compound 4, a percentage reported as activity, at one concentration (the size of the read-out at that concentration, not a potency): 98%
Beside the measured number, compound 4's estimate is 2 percentage points above it; low and high end bracket the measured number.
By their numbers in this assay, from the lowest: compounds 1, 3, 4 and 2 (each within the scatter of the next, the first and the last beyond it).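

Hydroxy to methoxy, with 3-chloro-5-hydroxyphenyl becoming 3-chloro-5-methoxyphenyl, now has a reading with nothing else altered in this assay: a number 7 percentage points lower from compound 2 to compound 4 (within the scatter). Compound 3 carries the same methoxy group but also differs at the urea aryl, so it could not isolate this change. With the dichlorophenyl urea held fixed, adding a methyl on this oxygen produces no readable change at the concentration tested, and no measurement at hand offers an explanation for this result.

Still open, on these data alone, is whether the same step holds on the urea aryl of compound 1, where the hydroxy compound has a separate value. Also open, as far as these compounds go, is whether an amine, a carboxylic acid or a longer ether chain such as ethoxy at this position would shift the read-out beyond the scatter.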